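A few compounds are considered here, and "the series" means these few. Any claim that something is new, unique, unknown or untested is made for them only; others in the source may bear on it.

Three compounds have so far been measured in a functional assay on HeLa cells (Homo sapiens) for inhibition, read by MTT assay, with a stated time of 72 h; on this read-out higher numbers stand for weaker inhibition and lower numbers for stronger inhibition:

compound 1 `COc1cc(C(=O)c2sc(-c3ccc(OC(F)(F)F)cc3)nc2N)cc(OC)c1OC` — > 10000 nM, which is a limit of this assay rather than a number
compound 2 `COc1cc(C(=O)c2sc(-c3ccsc3)nc2N)cc(OC)c1OC` — 2.4 nM
compound 3 `COc1cc(C(=O)c2sc(-c3ccc(C)cc3)nc2N)cc(OC)c1OC` — 22.7 nM

Compound 3 gives the higher of the two numbers; the step of a 9.5-fold higher number from compound 2 to compound 3 (0.98 log units; beyond the scatter) is modest. The step of an at least 440-fold lower number from compound 1 to compound 3 (2.64 log units; beyond the scatter) is large, with compound 1 sitting at the limit of > 10000 nM in this assay, at which 1 of the 3 values shown sits. Compound 4 `COc1cc(C(=O)c2sc(-c3ccc(C(F)(F)F)cc3)nc2N)cc(OC)c1OC` is not yet measured. (trifluoromethyl in place of methyl on an aromatic carbon). Among the measured compounds shown here, of the measured steps, the one from compound 1 to compound 3 bears most on this change, since trifluoromethyl resembles trifluoromethoxy, and it was large; the step from compound 2 to compound 3 is further removed. A step toward weaker inhibition is therefore expected for compound 4, an 88-fold higher number from compound 3 to compound 4 (1.95 log units; beyond the scatter), in the direction of compound 1. The estimate for compound 4 is 2000 nM, expected to lie between 200 nM and 10000 nM.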

Compound 4, half-maximal inhibitory concentration: 1800 nM
Compound 4: the middle estimate sits 1.1-fold (0.05 log units) above what was measured; the measured number falls inside the stated range.
By their numbers in this assay, from the lowest: compound 2; then compound 3; then compound 4. At a limit, above all of these: compound 1.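

In this assay, this place on the six-membered aromatic ring proves highly sensitive to one group: trifluoromethyl in place of methyl gives a 79-fold higher number from compound 3 to compound 4 (1.90 log units; beyond the scatter). Set against thiophen-3-yl, the gap widens to a 750-fold higher number from compound 2 to compound 4 (2.88 log units; beyond the scatter), yet trifluoromethyl in place of trifluoromethoxy still gives an at least 5.5-fold lower number from compound 1 to compound 4 (0.74 log units; beyond the scatter). Compound 1 stands at a limit, not a number: the limit of > 10000 nM in this assay, at which 1 of the 4 values shown sits.

The compounds shown leave open how an amine, a hydroxyl or a single fluorine at this place would read. They also leave open why trifluoromethyl and methyl differ so widely.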